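This account rests on a few compounds, and the source may have more. Where it says the series, first, only, none or still open, it means among the compounds named here.

In a functional assay on HeLa cells (Homo sapiens) for antiproliferative activity, read by MTT assay, with a stated time of 48 h (a higher number here means a weaker inhibitor, a lower number a stronger inhibitor), the three measured compounds stand as follows:

compound 1, `CCCn1c(N)c(-c2nc3ccccc3[nH]2)c2nc(C#N)c(C#N)nc21`: > 50000 nM, a limit of the assay
compound 2, `CN(C)CCCn1c(N)c(-c2nc3ccccc3[nH]2)c2nc(C#N)c(C#N)nc21`: 25900 nM
compound 3, `N#Cc1nc2c(-c3nc4ccccc4[nH]3)c(N)n(CCCN3CCCCC3)c2nc1C#N`: 6680 nM

Compound 1 thus has no number of its own, only the limit described in the limit of > 50000 nM in this assay, at which 1 of the 3 values shown sits. Compound 4, `N#Cc1nc2c(-c3nc4ccccc4[nH]3)c(N)n(CCCNc3ccccc3)c2nc1C#N`, differs from it in one place: anilino in place of hydrogen on a saturated chain carbon, three bonds along the chain from an aromatic nitrogen. Two measured steps start from the same hydrogen at the same position on the chain. The first, an at least 1.9-fold lower number from compound 1 to compound 2 (0.28 log units; that floor lies within the scatter), reaches only the edge of the scatter; the second, an at least 7.4-fold lower number from compound 1 to compound 3 (0.87 log units; beyond the scatter), goes clearly beyond it, and between the two substituted compounds a 3.9-fold lower number from compound 2 to compound 3 (0.59 log units; beyond the scatter) shows that the larger ring-bearing group gives the lower number. Anilino is again a ring-bearing group at this position, so a lower number than the limit of compound 1 is expected, though the anilino group is unlike the other two and no step with it has been measured. The expected step is an at least 3.3-fold lower number from compound 1 to compound 4 (0.52 log units; beyond the scatter). Compound 4 is therefore estimated at 15000 nM, within a range of 4000 nM to 50000 nM.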

Compound 4, half-maximal inhibitory concentration: 26300 nM
Estimate against measurement, compound 4: 1.8-fold (0.24 log units) below, and the stated range covers the measured number.
By their numbers in this assay, from the lowest: compound 3; then compounds 2 and 4 (each within the scatter of the next). At a limit, above all of these: compound 1.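

In this assay, anilino in place of hydrogen gives an at least 1.9-fold lower number from compound 1 to compound 4 (0.27 log units; that floor lies within the scatter), so this change is not shown to move the number beyond the scatter. A ring-bearing group on the chain does not by itself match piperidin-1-yl, as anilino gives a 3.9-fold higher number from compound 3 to compound 4 (0.60 log units; beyond the scatter), while it cannot be told apart from dimethylamino, with a 1.0-fold higher number from compound 2 to compound 4 (0.01 log units; within the scatter). Compound 1 has only a limit, so each step from it is a floor: the limit of > 50000 nM in this assay, at which 1 of the 4 values shown sits.

The compounds shown leave open whether a pyrrolidin-1-yl or morpholin-4-yl group at this place would match piperidin-1-yl. They also leave open whether a longer chain carrying piperidin-1-yl would change the number in this assay.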